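A few compounds are considered here, and "the series" means these few. Any claim that something is new, unique, unknown or untested is made for them only; others in the source may bear on it.

Measured so far in an assay on isolated protein for inhibition of cathepsin S (Homo sapiens); a higher number here means a weaker inhibitor, a lower number a stronger inhibitor:
compound 1 `N#C[C@@]1(NC(=O)[C@@H](CC(=O)N2CCOCC2)CC2CCCCC2)CCNC1`, 141 nM
compound 2 `N#C[C@H](CCc1ccccc1)NC(=O)[C@@H](CC(=O)N1CCOCC1)CC1CCCCC1`, 171 nM

Compound 1 carries the lowest of the two numbers, but its nearest neighbour, compound 2, lies within the scatter of it, so the two cannot be ranked. Among the compounds with values here, no single-point step between them is given.

Compound 3 `CC(C)N1CC[C@@](C#N)(NC(=O)[C@@H](CC(=O)N2CCOCC2)CC2CCCCC2)C1` differs from compound 1 by isopropyl in place of hydrogen on an amine nitrogen in a ring. Within the data shown here, no measured pair shows what this change does in this assay, so the expectation rests on compound 1 alone. The step of a 1.3-fold lower number from compound 1 to compound 3 (0.11 log units; within the scatter) is expected to stay within the scatter, in no clear direction. Compound 3 is therefore estimated at 110 nM, with a range from 35 nM to 350 nM.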

Compound 3, half-maximal inhibitory concentration: 66 nM
The estimate for compound 3 lay 1.7-fold (0.22 log units) above the measured number, and the stated range covers the measured number.
By their numbers in this assay, from the lowest: compound 3; then compounds 1 and 2 (each within the scatter of the next).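

In this assay, isopropyl in place of hydrogen on the amine nitrogen in the ring gives a 2.1-fold lower number from compound 1 to compound 3 (0.33 log units; beyond the scatter) as a modest step beyond the scatter. This nitrogen, two ring bonds from the ring atom that bears the cyano group, therefore takes an alkyl group without a rise in the number. Nothing measured here accounts for the step.

On these data alone, a single group cannot show a trend, so it remains open whether methyl, a longer chain or an acyl group on this nitrogen would move the number further.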